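This account rests on a few compounds, and the source may have more. Where it says the series, first, only, none or still open, it means among the compounds named here.

Compound 2, with the structure `O=C1O[C@H]([C@@H](O)Cn2c(=O)[nH]c(=O)[nH]c2=O)C(OCc2ccccc2)=C1OCc1ccccc1`, is one of two measured members of this small series, the other being compound 1, with the structure `Nc1ccn(C[C@H](O)[C@H]2OC(=O)C(OCc3ccccc3)=C2OCc2ccccc2)c(=O)n1`. In a functional assay on HeLa cells (Homo sapiens) for inhibition, read by MTT assay, with a stated time of 72 h (on this read-out higher numbers stand for weaker inhibition and lower numbers for stronger inhibition), compound 1 gives only a limit, > 100000 nM. In this assay compound 2 likewise gives only a limit, > 100000 nM. Within the data shown here, the one measured step, a step that the two limits leave unreadable from compound 1 to compound 2, therefore cannot be read in size, and compound 2 stands at the same limit as its only neighbour, as the evidence the limit of > 100000 nM in this assay, at which 2 of the 2 values shown sit, records.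

The unmeasured compound 3, with the structure `Nc1ncn(C[C@H](O)[C@H]2OC(=O)C(OCc3ccccc3)=C2OCc2ccccc2)c(=O)n1`, differs from compound 2 in one place: a group of 8 heavy atoms (3 carbon, 4 nitrogen, 1 oxygen; one six-membered aromatic ring with 3 hetero atoms) in place of a group of 9 heavy atoms (3 carbon, 3 nitrogen, 3 oxygen; one six-membered aromatic ring with 3 hetero atoms), on a saturated chain carbon, two bonds along the chain from an oxygen on a saturated carbon and a saturated ring carbon. Among the measured compounds shown here, no measured step bears on this change beyond the unreadable one from compound 1 to compound 2, and with both measured values sitting at the limit (the limit of > 100000 nM in this assay, at which 2 of the 2 values shown sit), no direction for the step in this assay can be drawn from the data. Compound 3 is therefore expected to sit near that same limit, with an estimated step that the limit leaves unreadable from compound 2 to compound 3. Compound 3 is estimated at 150000 nM, in a range from 30000 nM to 600000 nM, and the assay is expected most likely to report only a limit again.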

Compound 3, half-maximal inhibitory concentration: > 100000 nM
Compound 3: no number, only a limit; the forecaster's own chance of this, stated with the estimate: 80%; the middle value lies beyond the limit too.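

The steps among compound 1, compound 2 and compound 3 cannot be read, as all three give only a limit: the limit of > 100000 nM in this assay, at which 3 of the 3 values shown sit.

The compounds shown leave open how far each lies beyond that limit in this assay and whether any group at this place on the saturated chain carbon would give a readable value.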